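Exchanging One Group on Compound 2

The compounds below may be only part of what the source reports. "The series", "measured", "known", "first", "only" and "open" are said of these compounds alone.

Going by the values given here, in an ADME assay on MT4 cells (Homo sapiens) for cytotoxicity, read by MTT assay (on this read-out higher numbers stand for lower toxicity in this test and lower numbers for higher toxicity in this test), compound 2 (`Cc1cc(C)cc(S(=O)(=O)c2c(C(=O)NCc3ccccc3N)[nH]c3ccc(Cl)cc23)c1`) gives 46200 nM and holds the highest of the two true numbers so far. On the same scale compound 1 (`Cc1cc(C)cc(S(=O)(=O)c2c(C(=O)Nc3ccccc3O)[nH]c3ccc(Cl)cc23)c1`) reads 19700 nM and sits lower. Compound 3 (`Cc1cc(C)cc(S(=O)(=O)c2c(C(=O)NCc3cccc(O)c3)[nH]c3ccccc23)c1`) returned only a limit of the assay (> 5190 nM) and not a number.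

The next compound to be tested is compound 4 (`Cc1cc(C)cc(S(=O)(=O)c2c(C(=O)NCc3ccc(O)cc3)[nH]c3ccc(Cl)cc23)c1`), which differs from compound 2 in one place. It carries 4-hydroxyphenyl in place of 2-aminophenyl on a saturated chain carbon bound to an amide-type nitrogen. Cut one bond further out, the same difference reads 2-aminobenzyl to 4-hydroxybenzyl.

Among the compounds with values here, only one measured step bears on this change. It also involves 2-aminobenzyl, which there stands in place of 2-hydroxyphenyl on an amide-type nitrogen (a 2.3-fold higher number from compound 1 to compound 2 (0.37 log units; beyond the scatter)). That step is modest, though beyond the scatter, and it is not the same exchange, so it offers only a rough guide to size. On the strength of that modest step, a change of no greater size is expected, most likely a slightly lower number or none beyond the scatter. The estimated step is small (a 1.4-fold lower number from compound 2 to compound 4 (0.15 log units; within the scatter)) and stays within what repeated measurements could show. For compound 4 the expected value is 33000 nM (estimated range 11000 nM to 90000 nM).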

Compound 4, half-maximal cytotoxic concentration: 6250 nM
Beside the measured number, compound 4's estimate is 5.3-fold (0.72 log units) above it; measured number below the stated range.
By their numbers in this assay, from the lowest: compound 4; then compound 1; then compound 2.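

In this assay, exchanging 2-aminobenzyl for 4-hydroxybenzyl on the amide-type nitrogen gives a clear change (a 7.4-fold lower number from compound 2 to compound 4 (0.87 log units; beyond the scatter)), so this position responds even to a swap in which the leaving and entering groups have the same counts of heavy atoms, donors and acceptors. Set against 2-hydroxyphenyl on that nitrogen, 4-hydroxybenzyl also moves the reading toward higher toxicity in this test (a 3.2-fold lower number from compound 1 to compound 4 (0.50 log units; beyond the scatter)), which makes compound 4 the lowest of the three true numbers and shows that carrying a hydroxy-bearing ring does not by itself fix the reading, since compound 1 carries one too. Nothing measured here accounts for the shift.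

Compound 3 gives only a limit of the assay (> 5190 nM) and so adds no true number to this comparison. On these data alone, it stays open whether the shift follows the exchange of the amino group for the hydroxyl or the move from the 2 to the 4 place in the name, and 4-aminobenzyl or 2-hydroxybenzyl on the same nitrogen would pull those two apart.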